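The source may hold more compounds than are shown below. What is called first, only, known or untested is meant among the compounds shown, and "the series" means these compounds.

Compound 1 `CCCCCCCCC[C@@H](O)[C@@H](N)[C@@H](C)CC`: 2300 nM
Compound 2 `CCCCCCCCCCCCCCC[C@@H](O)[C@H](C)N`: 700 nM

Both numbers come from a functional assay on WiDr cells (Homo sapiens) for antiproliferative activity, read by sulforhodamine B assay, with a stated time of 48 h; on this read-out lower numbers stand for stronger inhibition of growth and higher numbers for weaker inhibition of growth. Compound 1 stands with the higher of the two numbers; compound 2 gives the lower one, and the gap between them lies beyond the usual scatter. Compound 3 `CCCCCCCCC[C@@H](O)[C@@H](N)[C@@H](C)O` is not yet measured. It differs from compound 1 in one place: hydroxy in place of ethyl on a saturated chain carbon bound to two saturated chain carbons. Among the measured compounds shown here, no measured pair shows this same change, so the step of a 1.5-fold higher number from compound 1 to compound 3 (0.18 log units; within the scatter) is an expectation only, set as a small move toward a higher number, close to the edge of the scatter. Compound 3 is accordingly estimated at 3500 nM, within a range from 1500 nM to 9000 nM.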

Compound 3, concentration for 50% growth inhibition: 14000 nM
The estimate for compound 3 lay 4.0-fold (0.60 log units) below the measured number; measured number above the stated range.
By their numbers in this assay, from the lowest: compound 2; then compound 1; then compound 3.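

In this assay, among the compounds shown here, hydroxy in place of ethyl on a saturated chain carbon bound to two saturated chain carbons gives a 6.1-fold higher number from compound 1 to compound 3 (0.78 log units; beyond the scatter) and so shows that growth inhibition at this position depends on the group it carries, which the earlier compounds could not show. Here, ethyl gives stronger inhibition than hydroxy. No supporting measurement accounts for this difference.

This single swap cannot separate losing ethyl from gaining hydroxy. Going by these compounds, how a methoxy group, an amine or a longer chain would fare at this place remains open.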